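The source may hold more compounds than are shown below. What is called first, only, known or untested is meant among the compounds shown, and "the series" means these compounds.

Compound 2, with structure `COc1ccc(N2C[C@@H](C)N[C@@H](C)C2)cc1NS(=O)(=O)c1ccc(-c2cccs2)cc1`, gives 3.98 nM in a functional assay for agonist activity at growth hormone secretagogue receptor type 1 (Homo sapiens), read by FLIPR (a lower number here means that less compound is needed, a higher number that more compound is needed for the effect), and stands highest of the two numbers measured there. Within the data shown here, its nearest neighbour is compound 1, with structure `COc1ccc(F)c(-c2ccc(S(=O)(=O)Nc3cc(N4C[C@@H](C)N[C@@H](C)C4)ccc3OC)cc2)c1`, which gives 0.398 nM in this assay; the only measured step, a 10-fold higher number from compound 1 to compound 2 (1.00 log units; beyond the scatter), comes from a change at a different place, the swap of one aromatic group for another. Compound 3, with structure `COc1ccc(N2C[C@@H](C)N[C@@H](C)C2)cc1NS(=O)(=O)c1ccc(-c2cccs2)cc1F`, differs from compound 2 by fluoro in place of hydrogen on an aromatic carbon. Among the measured compounds shown here, no measured pair tracks the addition of a single fluoro to the ring bearing the sulfonamide, so the one measured step offers no direct guide, and a small fluoro added in this way gives no reason to expect a change beyond the scatter in this assay. Compound 3 is therefore expected to stay close to compound 2, with an estimated step of a 1.0-fold higher number from compound 2 to compound 3 (0.00 log units; within the scatter). The estimate for compound 3 is 4 nM, within a range of 1.3 nM to 12 nM.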

Compound 3, half-maximal effective concentration: 2 nM
Beside the measured number, compound 3's estimate is 2.0-fold (0.30 log units) above it; the measured number falls inside the stated range.
By their numbers in this assay, from the lowest: compound 1; then compounds 3 and 2 (each within the scatter of the next).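

In this assay, fluoro in place of hydrogen on the aromatic carbon ortho to a large group and meta to the thiophen-2-yl group gives a 2.0-fold lower number from compound 2 to compound 3 (0.30 log units; within the scatter), so this first measured change at this position cannot be told from the scatter. The earlier step, a 10-fold higher number from compound 1 to compound 2 (1.00 log units; beyond the scatter), lay beyond the scatter but came from swapping the aromatic group itself, and it said nothing about this ring position. No measurement shown here bears on the reason for this result.

The compounds shown leave open whether a larger group at this position, such as methoxy, trifluoromethyl or an amine, would give a step beyond the scatter. They also leave open whether the same fluoro would give a similar step in compound 1, which carries 2-fluoro-5-methoxyphenyl in place of thiophen-2-yl.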